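Series notes: phenyl replacing cyclohexyl at the amine carbon

The source may hold more compounds than are shown below. What is called first, only, known or untested is meant among the compounds shown, and "the series" means these compounds.

Measured so far:
compound 1 `CC(C)C(C)Nc1nc(O)c2cc(Cl)ccc2n1`: 16300 nM in a functional assay (aorta) for inhibition, with Rattus norvegicus as the target; a lower number here means a stronger inhibitor, a higher number a weaker inhibitor
compound 2 `C[C@@H](Nc1nc(O)c2cc(Cl)ccc2n1)C1CCCCC1`: 5600 nM
compound 3 `C[C@H](Nc1nc(O)c2cc(Cl)ccc2n1)C1CCCCC1`: 2100 nM

Compound 3 stands lowest of the three numbers; compound 2 is nearest, compound 1 furthest. Within the data shown here, the one measured single change is the inversion of configuration, a 2.7-fold lower number from compound 2 to compound 3 (0.43 log units; beyond the scatter), a modest step that rests on (the fact that compounds 2 and 3 differ only in the configuration as drawn). Compound 1 and compound 3 differ in more than one place, so their two values are only compared as they stand, compound 1 being the higher one.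

Compound 4 `C[C@H](Nc1nc(O)c2cc(Cl)ccc2n1)c1ccccc1` differs from compound 3 by phenyl in place of cyclohexyl on a saturated chain carbon bound to a nitrogen on an aromatic ring and a saturated chain carbon. Among the measured compounds shown here, no measured step in this set exchanges one ring for another, so none bears directly on this change; the measured steps give no size to carry over. Compound 4 is therefore expected to stay close to compound 3, with no step beyond the scatter predicted in either direction, a 1.4-fold higher number from compound 3 to compound 4 (0.15 log units; within the scatter), and a wide range. Compound 4 is estimated at 3000 nM, between 700 nM and 13000 nM.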

Compound 4, half-maximal inhibitory concentration: 1700 nM
Compound 4: the middle estimate sits 1.8-fold (0.25 log units) above what was measured; measured number inside the range.
By their numbers in this assay, from the lowest: compounds 4 and 3 (each within the scatter of the next); then compound 2; then compound 1.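

In this assay, the ring exchange at this saturated chain carbon gives a 1.2-fold lower number from compound 3 to compound 4 (0.09 log units; within the scatter), so with the drawn configuration of compound 3 held, phenyl and cyclohexyl cannot be told apart here. Among these compounds, this is the first ring-for-ring exchange, and it shows that a six-membered aromatic ring of carbon only serves at this position as well as the non-aromatic ring with the same heavy-atom count. No measured property of either ring is available to account for this result.

From the compounds shown here alone, whether a pyridyl ring or a methoxy-bearing phenyl would stay as close to these two compounds remains open. Also open, going by these compounds, is whether the phenyl compounds would repeat the configuration step seen in the cyclohexyl pair, a 2.7-fold lower number from compound 2 to compound 3 (0.43 log units; beyond the scatter).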